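A few compounds are considered here, and "the series" means these few. Any claim that something is new, unique, unknown or untested is made for them only; others in the source may bear on it.

In a functional assay on PC-3 cells (Homo sapiens) for inhibition, read by sulforhodamine B assay, with a stated time of 48 h (a higher number here means a weaker inhibitor of growth, a lower number a stronger inhibitor of growth), the measured compounds read as follows:
- compound 1 `COc1ccc(/C=C/C2(C)C=CC(=O)O2)c(OC)c1` gives 63500 nM
- compound 2 `COc1ccc(/C=C/C2(C)C=CC(=O)O2)cc1OC` gives 176000 nM
- compound 3 `COc1ccc(/C=C/C2(C)C=CC(=O)O2)c(OC)c1OC` gives 90000 nM

Compound 2 carries a higher number than compound 1, a gap beyond the scatter. Compound 4 `COc1cc(OC)c(OC)cc1/C=C/C1(C)C=CC(=O)O1` comes from compound 2 by methoxy in place of hydrogen on an aromatic carbon. The same kind of change gave a 2.0-fold lower number from compound 2 to compound 3 (0.29 log units; within the scatter) and also a 1.4-fold higher number from compound 1 to compound 3 (0.15 log units; within the scatter). These steps run in opposite directions, and neither places the methoxy as in compound 4. No step beyond the scatter is therefore expected in this assay, with a slight lean towards a lower number. The expected change is a 1.6-fold lower number from compound 2 to compound 4 (0.20 log units; within the scatter). Compound 4 is estimated at 110000 nM, with an expected range of 50000 nM to 240000 nM.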

Compound 4, concentration for total growth inhibition: 184000 nM
The estimate for compound 4 lay 1.7-fold (0.22 log units) below the measured number, and the stated range covers the measured number.
By their numbers in this assay, from the lowest: compounds 1, 3, 2 and 4 (each within the scatter of the next, the first and the last beyond it).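

Methoxy in place of hydrogen at this position, para to a methoxy group, gives a 1.0-fold higher number from compound 2 to compound 4 (0.02 log units; within the scatter) in this assay, while the wider comparison gives a 2.9-fold higher number from compound 1 to compound 4 (0.46 log units; beyond the scatter), the only step of this change beyond the scatter. One pairing of the steps agrees across the two cores: the same change on two cores in this assay, a 1.4-fold higher number (0.15 log units; within the scatter) from compound 1 to compound 3 and a 1.0-fold higher number (0.02 log units; within the scatter) from compound 2 to compound 4, 1.4-fold (0.13 log units) apart, within the scatter of two such steps. The other pairing does not agree: the same change on two cores in this assay, a 2.0-fold lower number (0.29 log units; within the scatter) from compound 2 to compound 3 and a 2.9-fold higher number (0.46 log units; beyond the scatter) from compound 1 to compound 4, 5.7-fold (0.75 log units) apart, beyond the scatter of two such steps.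

Going by these compounds, whether an amine or a carboxylic acid at this position would move the number stays open. The shown substituents on the aromatic ring are limited to methoxy.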